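The source may hold more compounds than are shown below. What is called first, only, known or untested is meant among the compounds shown, and "the series" means these compounds.

Compound 1 `Cc1cc(C)c2sc(NC(=O)c3ccc(C#N)cc3)nc2c1` gives 290 nM in growth inhibition
Compound 2 `Cc1cc(C)c2sc(NC(=O)c3ccc([N+](=O)[O-])cc3)nc2c1` gives 290 nM in growth inhibition

Both values come from a functional assay on SK-HEP1 cells (Homo sapiens) for inhibition (a higher number here means a weaker inhibitor of growth, a lower number a stronger inhibitor of growth), and they stand level. Compound 2 reads 290 nM and matches compound 1 at the digits given, so neither can be placed ahead of the other.

The next compound, compound 3 `Cc1cc(C)c2sc(NC(=O)c3ccc(C(F)(F)F)cc3)nc2c1`, keeps the shared core and the amide of compound 2 and alters a single group: trifluoromethyl in place of nitro on an aromatic carbon, para to a large group (trifluoromethyl in place of nitro on an aromatic carbon).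

Among the compounds with values here, only one measured step bears on this change. It also swaps one group on an aromatic carbon, nitro in place of cyano, and it reads no change at the digits printed from compound 1 to compound 2 (within the scatter) in this assay as its result. That is a single pair, and trifluoromethyl has not yet been measured on this core, so the evidence is thin. Going by that step, no change beyond the scatter is expected, and no direction can be called. The expected outcome is a 1.0-fold higher number from compound 2 to compound 3 (0.01 log units; within the scatter) and it remains an estimate. For compound 3 the estimate is 300 nM with 120 nM to 750 nM as its expected range.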

Compound 3, concentration for 50% growth inhibition: 290 nM
For compound 3 the middle estimate is 1.0-fold (0.01 log units) above the measured one; low and high end bracket the measured number.
By their numbers in this assay, from the lowest: compounds 1, 2 and 3 (each within the scatter of the next).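

In this assay, the para position now holds three different groups with no separation among them: trifluoromethyl gives no change at the digits printed from compound 2 to compound 3 (within the scatter), and against the nitrile it gives no change at the digits printed from compound 1 to compound 3 (within the scatter). Within the data shown here, this is the first step at this place to bring in a group with 0 hydrogen-bond acceptors in place of one with 2, and to go from 3 heavy atoms to 4, and growth inhibition stays level across that difference, so nitrile, nitro and trifluoromethyl cannot be ranked on these numbers. No measurement of any property of these groups accompanies the growth data, so nothing here accounts for the level readings.

The compounds shown leave open whether this level holds for a quite different group at the same place, such as an amine, a carboxylic acid or a plain hydrogen, any of which could show whether this position responds at all. Going by these compounds, all three compounds also share the same core and amide, so what the methyl groups on that core or the amide hydrogen contribute to growth inhibition remains unknown.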